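The compounds below may be only part of what the source reports. "The series", "measured", "known", "first", "only" and "open" are said of these compounds alone.

In a functional assay on A549 cells (Homo sapiens) for cytotoxicity, read by MTT assay, with a stated time of 72 h (on this read-out lower numbers stand for stronger inhibition and higher numbers for weaker inhibition), compound 2 (`CNC(=O)c1cc(Oc2ccc(NC(=O)c3nccc(-c4ccc([N+](=O)[O-])cc4)n3)cc2)ccn1`) gives > 100000 nM, a limit of the assay and not a number. Compound 2 sits on (the limit of > 100000 nM in this assay, at which 2 of the 3 values shown sit). Compound 4 (`CNC(=O)c1cc(Oc2ccc(NC(=O)c3nccc(-c4ccc(C)cc4)n3)cc2)ccn1`) carries methyl in place of nitro on an aromatic carbon, para to a large group: methyl in place of nitro on an aromatic carbon. Among the measured compounds shown here, no measured step covers this exchange. The nearest evidence is compound 1 (`CNC(=O)c1cc(Oc2ccc(NC(=O)c3cc(-c4ccc(C)cc4)ncn3)cc2)ccn1`), which has the same 4-methylphenyl group on a different core and gives > 100000 nM, also a limit of the assay. Compound 3 (`CNC(=O)c1cc(Oc2ccc(NC(=O)c3cc(-c4ccc(C)cc4)ncn3)cc2F)ccn1`) also has 4-methylphenyl and gives 13200 nM. For the measured compounds named here, the only measured step is an at least 7.5-fold lower number from compound 1 to compound 3 (0.87 log units; beyond the scatter), for fluoro in place of hydrogen on an aromatic carbon, and compound 4 lacks that fluoro. A clear move toward lower numbers in this assay is therefore not expected, and a reading at the limit remains more likely than not. The expected step is an at least 1.4-fold lower number from compound 2 to compound 4 (0.15 log units; that floor lies within the scatter). Compound 4 is estimated at 70000 nM, with an expected range of 20000 nM to 100000 nM.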

Compound 4, half-maximal inhibitory concentration: 28400 nM
Compound 4: the middle estimate sits 2.5-fold (0.39 log units) above what was measured; the range from low to high includes it.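

In this assay, the exchange of 4-nitrophenyl for 4-methylphenyl gives an at least 3.5-fold lower number from compound 2 to compound 4 (0.54 log units; beyond the scatter), so on the shared core this position is sensitive to the group it carries. Among the compounds shown here, the only earlier step was a fluoro exchange, which said nothing about this position. Compound 2 gives > 100000 nM, a limit of the assay and not a number, so the step has a floor but no measured size: the limit of > 100000 nM in this assay, at which 2 of the 4 values shown sit.

With only nitro and methyl shown at this position, the compounds do not show how an amine or a carboxylic acid there would read. From the compounds shown here alone, it also stays open whether fluoro in place of hydrogen, which gave an at least 7.5-fold lower number from compound 1 to compound 3 (0.87 log units; beyond the scatter) on another core, would lower the number on the core of compound 4.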